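A few compounds are considered here, and "the series" means these few. Any claim that something is new, unique, unknown or untested is made for them only; others in the source may bear on it.

Measured compounds:
Compound 1, `COC(=O)c1ccc(NCc2nc(N)c3cc(OC)c(OC)cc3n2)cc1`, gives 138 nM in an assay on thoracic aorta (strain Wistar) for antagonist activity at Adrenergic receptor alpha-1 (Rattus norvegicus), with a stated time of 30 min; a higher number here means weaker binding, a lower number tighter binding.
Compound 2, `COc1cc2nc(N3CCN(C)CC3)nc(N)c2cc1OC`, gives 0.589 nM in this assay.

Of the two numbers measured in this assay, compound 2 holds the lowest. Among the compounds with values here, its only neighbour is compound 1, whose value stands far higher, and that gap lies well beyond the usual scatter, so compound 2 is the tighter binder of the pair by a clear margin. Within the data shown here, no step between the two measured compounds is recorded, since they differ in more than one place.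

The piece now turns to compound 3, `COc1cc2nc(N3CCN(c4ccccc4F)CC3)nc(N)c2cc1OC`, which has not yet been measured. Compound 3 differs from compound 2 in a single place: 2-fluorophenyl in place of methyl on an amine nitrogen in a ring. The shared core of compound 2 and compound 3 is kept unchanged. Since nothing measured here traces this particular exchange, the direction of the step is open. Given that compound 2 gives 0.589 nM in this assay, compound 3 is expected to stay close to it, with a step of a 1.2-fold lower number from compound 2 to compound 3 (0.07 log units; within the scatter) estimated to lie within the scatter. The estimate for compound 3 in this assay is 0.5 nM, with a range from 0.1 nM to 3 nM.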

Compound 3, dissociation constant: 0.0309 nM
Estimate against measurement, compound 3: 16-fold (1.21 log units) above; the measured number lies below the stated range.
By their numbers in this assay, from the lowest: compound 3; then compound 2; then compound 1.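

In this assay, the amine nitrogen in the six-membered ring proves open to far more than a single carbon: with the shared core unchanged, 2-fluorophenyl in place of methyl brings a 19-fold lower number from compound 2 to compound 3 (1.28 log units; beyond the scatter) and marks this as a position where a change moves the number strongly. This is the only single-place change among the compounds shown, and it establishes that a six-membered aromatic ring of carbon only, carrying fluorine, is accepted here and goes with tighter binding than methyl. No measurement given here bears on why the number falls, so the step stands as an observation without an explanation.

The compounds shown leave open how much of the step belongs to the aromatic ring and how much to the fluorine, a split that a plain phenyl group on the same nitrogen would begin to settle. Also open, going by these compounds, are whether a benzyl or benzoyl group in that place would follow compound 3, and whether a chlorine or a methoxy group could stand in for the fluorine.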